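A few compounds are considered here, and "the series" means these few. Any claim that something is new, unique, unknown or untested is made for them only; others in the source may bear on it.

The compounds here are read in a functional assay on DU-145 cells (Homo sapiens) for inhibition, read by MTT assay, with a stated time of 48 h; on this read-out lower numbers stand for stronger inhibition of growth and higher numbers for weaker inhibition of growth. Compound 1, `C#CCN(C)Cc1cccc(NC(=O)CCCCCC(=O)NO)c1`, gives 4290 nM in this assay and so stands at a measured number. Compound 2, `C#CCN(C)Cc1ccc(NC(=O)CCC(=O)NO)cc1`, returns only a limit of this assay, > 10000 nM, and therefore no number. Of the two values shown, compound 2 is the one that sits at the limit of > 10000 nM in this assay, at which 1 of the 2 values shown sits, while compound 1 carries a measured value. Among the measured compounds shown here, no step between measured compounds is on record here, since compound 1 and compound 2 differ in more than one place.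

Compound 3, `C#CCN(C)Cc1ccc(NC(=O)CCCCC(=O)NO)cc1`, is not yet measured. It differs from compound 2 by 2-(hydroxycarbamoyl)ethyl in place of hydroxycarbamoyl on a saturated chain carbon, two bonds along the chain from a carbonyl carbon. The step from compound 2 to compound 3 is expected to be an at least 2.5-fold lower number from compound 2 to compound 3 (0.39 log units; beyond the scatter), that is, a move toward stronger inhibition of growth that goes beyond the usual scatter. Compound 1, which also carries a longer chain before its hydroxycarbamoyl end, gives 4290 nM in this assay, and the expectation for compound 3 follows that measured value. Compound 3 is thus estimated to give about 4000 nM in this assay, with a range from 1200 nM to 10000 nM.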

Compound 3, concentration for 50% growth inhibition: > 10000 nM
Compound 3: only a limit was reported (the forecaster's own chance of this, stated with the estimate: 25%); middle value at least 2.5-fold (0.39 log units) from the limit.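

In this assay compound 3 gives > 10000 nM, which is a limit and not a number. No step can be read between compound 2 and compound 3, because both stand at a limit: the limit of > 10000 nM in this assay, at which 2 of the 3 values shown sit.

The compounds shown leave open whether lengthening the chain on the shared core changes growth inhibition at all.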